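Series notes: 4-methylcyclohexyl amide, compound 4 expected

The source may hold more compounds than are shown below. What is called first, only, known or untested is meant among the compounds shown, and "the series" means these compounds.

Compound 1 `COc1cccc(OC)c1C(=O)Nc1c[nH]nc1C(=O)N[C@H]1CC[C@H](OC)CC1` is measured in an ADME assay on MRC5 cells (Homo sapiens) for inhibition, with a stated time of 72 h (on this read-out higher numbers stand for an effect only at larger amounts of compound and lower numbers for an effect already at smaller amounts), at 31000 nM. Compound 2 `COc1cccc(OC)c1C(=O)Nc1c[nH]nc1C(=O)N[C@H]1CC[C@H](O)CC1` gives 34000 nM in this assay, and compound 3 `COc1cccc(OC)c1C(=O)Nc1c[nH]nc1C(=O)NC1CCCCCC1` gives 42000 nM. Compound 1 is not set apart from either neighbour: the step of a 1.1-fold higher number from compound 1 to compound 2 (0.04 log units; within the scatter) and the step of a 1.4-fold higher number from compound 1 to compound 3 (0.13 log units; within the scatter) both stay within the scatter, as does a 1.2-fold higher number from compound 2 to compound 3 (0.09 log units; within the scatter), so the three values are indistinguishable on this read-out.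

Compound 4 `COc1cccc(OC)c1C(=O)Nc1c[nH]nc1C(=O)NC1CCC(C)CC1` differs from compound 1 by 4-methylcyclohexyl in place of 4-methoxycyclohexyl on an amide-type nitrogen. Within the data shown here, two measured steps bear on this change: the step to compound 2, which alters the group on the oxygen of the same ring, and the step to compound 3, which replaces the whole ring substituent with cycloheptyl; both were within the scatter. The loss of the oxygen in going to 4-methylcyclohexyl is covered by neither step exactly, but nothing measured suggests this position moves the number.

Compound 4 is therefore expected to give 34000 nM in this assay, with a range of 17000 nM to 68000 nM. The estimated step of a 1.1-fold higher number from compound 1 to compound 4 (0.04 log units; within the scatter) is expected to lie within the scatter.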

Compound 4, half-maximal effective concentration: 45000 nM
Estimate against measurement, compound 4: 1.3-fold (0.12 log units) below, within the range that was stated.
By their numbers in this assay, from the lowest: compounds 1, 2, 3 and 4 (each within the scatter of the next).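

In this assay, 4-methylcyclohexyl in place of 4-methoxycyclohexyl on the amide-type nitrogen gives a 1.5-fold higher number from compound 1 to compound 4 (0.16 log units; within the scatter), so the oxygen of the group that leaves is not required for a number in this range. The comparison with the 4-hydroxycyclohexyl amide gives a 1.3-fold higher number from compound 2 to compound 4 (0.12 log units; within the scatter), and the comparison with the cycloheptyl amide gives a 1.1-fold higher number from compound 3 to compound 4 (0.03 log units; within the scatter), so the four groups at this place, with and without oxygen, cannot be told apart on this read-out. No measurement at hand gives a reason for this flat picture.

Going by these compounds, whether an amine or a carboxylic acid on the cyclohexyl ring would stay within the same range remains open. The same applies to a longer chain, such as n-hexyl, on the amide-type nitrogen.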